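Methyl to hydrogen on the aryl ring of the core

This account rests on a few compounds, and the source may have more. Where it says the series, first, only, none or still open, it means among the compounds named here.

Measured compounds:
compound 1 `COc1ccc(-c2nc3sc(Cc4ccc(Cl)cc4)nn3c2SC#N)cc1`, 16000 nM
compound 2 `Cc1ccc(-c2nc3sc(Cc4ccc(Cl)cc4)nn3c2SC#N)cc1`, 32000 nM

Among the measured compounds shown here, compound 2 holds the highest of the two numbers in a functional assay on L1210 cells (Mus musculus) for cytotoxicity, with a stated time of 48 h (on this read-out lower numbers stand for stronger inhibition and higher numbers for weaker inhibition), yet the only step so far, a 2.0-fold higher number from compound 1 to compound 2 (0.30 log units; within the scatter), lies within the scatter. Compound 3 `N#CSc1c(-c2ccccc2)nc2sc(Cc3ccc(Cl)cc3)nn12` differs from compound 2 by hydrogen in place of methyl on an aromatic carbon. The step from methoxy to methyl at the same place is the only one that bears on this change, and it stayed within the scatter, so no step beyond the scatter is expected here. Compound 3 is estimated at 30000 nM, with a range from 12000 nM to 80000 nM. This estimate means an expected step of a 1.1-fold lower number from compound 2 to compound 3 (0.03 log units; within the scatter).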

Compound 3, half-maximal inhibitory concentration: 24000 nM
Estimate against measurement, compound 3: 1.3-fold (0.10 log units) above, within the range that was stated.
By their numbers in this assay, from the lowest: compounds 1, 3 and 2 (each within the scatter of the next).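

In this assay hydrogen in place of methyl gives a 1.3-fold lower number from compound 2 to compound 3 (0.12 log units; within the scatter) and hydrogen in place of methoxy gives a 1.5-fold higher number from compound 1 to compound 3 (0.18 log units; within the scatter) at the same aromatic carbon. The unsubstituted phenyl thus joins 4-methylphenyl and the methoxy analogue as three groups that this read-out does not separate, so this position shows no dependence on these three substituents. No available evidence bears on this result. Still open, from the compounds shown here alone, is whether an amine or a carboxylic acid at this carbon would give a step beyond the scatter.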